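The compounds below may be only part of what the source reports. "The series", "measured", "known", "first", "only" and "open" are said of these compounds alone.

Measured in a functional assay on A2780 cells (Homo sapiens) for cytotoxicity, read by MTT assay, with a stated time of 48 h; on this read-out lower numbers stand for stronger inhibition and higher numbers for weaker inhibition:

- compound 1 `COc1ccc(CNC(=O)CC2c3ccccc3N=C(N(C)CCCCCN(C)C)N2c2ccc(-c3ccccc3)cc2)cc1` gives 1380 nM
- compound 2 `Cc1ccc(CNC(=O)CC2c3ccccc3N=C(N3CCN(CCN(C)C)CC3)N2c2ccc(-c3ccccc3)cc2)cc1` gives 1600 nM

Going by the values given here, only these two compounds have numbers so far, and no pair among them differs in a single place. In this assay compound 2 and compound 1 sit within the usual scatter of each other, so the two numbers cannot be told apart with confidence.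

Compound 3 `CN(C)CCN1CCN(C2=Nc3ccccc3C(CC(=O)NCc3ccccn3)N2c2ccc(-c3ccccc3)cc2)CC1` is not yet measured. It differs from compound 2 in one place: pyridin-2-yl in place of 4-methylphenyl on a saturated chain carbon bound to an amide-type nitrogen. Among the compounds with values here, no measured pair shows what this kind of swap does on the shared core, so there is no step to lean on. The change is small in size and keeps the rest of the molecule intact, so the expected step is within the scatter, with no clear direction; the estimate for the step is a 1.1-fold higher number from compound 2 to compound 3 (0.05 log units; within the scatter). Compound 3 is therefore expected to give about 1800 nM in this assay, most likely between 700 nM and 5000 nM.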

Compound 3, half-maximal inhibitory concentration: 4860 nM
The estimate for compound 3 lay 2.7-fold (0.43 log units) below the measured number; the range from low to high includes it.
By their numbers in this assay, from the lowest: compounds 1 and 2 (each within the scatter of the next); then compound 3.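

In this assay, the swap of 4-methylphenyl for pyridin-2-yl on a saturated chain carbon bound to an amide-type nitrogen gives a 3.0-fold higher number from compound 2 to compound 3 (0.48 log units; beyond the scatter). Going by these compounds alone, this is the first sign that this position responds to a change at all, even though the swap leaves the rest of the molecule intact and alters the ring by only one atom and the methyl group. Nothing shown explains why the number rises, so the step records an effect without a cause.

This swap removes the methyl group and brings in the ring nitrogen together, so a plain phenyl group would help show which of the two changes matters. Also open, on these data alone, is whether pyridin-4-yl, with its nitrogen elsewhere in the ring, would give a similar step.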